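One More Hydroxy on the Aromatic Ring

The compounds below may be only part of what the source reports. "The series", "measured", "known", "first", "only" and "open" are said of these compounds alone.

In an assay on membranes from brain for displacement of a labelled ligand from adenosine receptor A1 (Rattus norvegicus), read by radioligand binding (a higher number here means a weaker inhibitor, a lower number a stronger inhibitor), compound 2 `COc1cccc2c1C/C(=C\c1cccc(O)c1)C2=O` gives 41 nM, the lower of the two numbers recorded so far. Compound 1 `O=C1/C(=C/c2ccc(O)c(O)c2)Cc2c(O)cccc21` gives 435 nM, a gap that lies beyond the usual scatter. Compound 3 `COc1cccc2c1C/C(=C\c1ccc(O)c(O)c1)C2=O` differs from compound 2 by hydroxy in place of hydrogen on an aromatic carbon. For the measured compounds named here, no step between measured compounds isolates this change, and compound 1 differs from compound 2 in two places, so its number cannot be tied to the added hydroxy alone. A modest weakening is expected, amounting to a 2.2-fold higher number from compound 2 to compound 3 (0.34 log units; beyond the scatter) in this assay. Compound 3 is therefore estimated at 90 nM, within 30 nM to 300 nM.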

Compound 3, inhibition constant: 42 nM
Compound 3: middle estimate off by 2.1-fold (0.33 log units), on the high side; the range from low to high includes it.
By their numbers in this assay, from the lowest: compounds 2 and 3 (each within the scatter of the next); then compound 1.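

At this position, ortho to a hydroxy group and para to a large group, hydroxy in place of hydrogen on an aromatic carbon is tolerated in this assay, with a 1.0-fold higher number from compound 2 to compound 3 (0.01 log units; within the scatter). The earlier pair could not separate its two differences, but methyl in place of hydrogen on an oxygen on an aromatic ring now stands alone, with a 10-fold lower number from compound 1 to compound 3 (1.02 log units; beyond the scatter).

On these data alone, whether an amine or a carboxylic acid on that carbon, or a longer chain on that oxygen, would fare alike remains open. Nothing available explains the size of either step.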